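Urea-piperidine series: oxanyl amide and ring fluorine

The source may report more compounds than this note shows. Statements on the series, on what has been measured and on what is new or still open speak of the compounds shown alone.

Compound 1 `O=C(Nc1ccc(OC(F)(F)F)cc1)NC1CCN(C(=O)C2CCOCC2)CC1` carries a trifluoromethoxy phenyl urea on a piperidine bearing an oxan-4-yl carbonyl. In an ADME assay on the whole organism (Mus musculus) for metabolic stability, at a dose of 0.3 mg/kg by the oral route (on this read-out lower numbers stand for a shorter-lived compound and higher numbers for a longer-lived compound), compound 1 gives 6.3 h. Compound 2 `O=C(Nc1ccc(OC(F)(F)F)c(F)c1)NC1CCN(C(=O)C2CCOCC2)CC1` adds a fluoro on the aromatic ring; in this assay compound 2 gives 4.3 h. Compound 3 `O=C(Nc1ccc(OC(F)(F)F)c(F)c1)NC1CCN(C(=O)C2CCCOC2)CC1` keeps that fluoro and moves the ring oxygen of the amide substituent: oxan-3-yl in place of oxan-4-yl on a carbonyl carbon. In this assay compound 3 gives 3.2 h.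

The difference between the two cores is thus (oxan-3-yl in place of oxan-4-yl on a carbonyl carbon), and the step it made is a 1.3-fold lower number from compound 2 to compound 3 (0.13 log units; within the scatter). Removing the ring fluorine is the change (hydrogen in place of fluoro on an aromatic carbon), which made the step of a 1.5-fold higher number from compound 2 to compound 1 (0.17 log units; within the scatter).

Compound 4 `O=C(Nc1ccc(OC(F)(F)F)cc1)NC1CCN(C(=O)C2CCCOC2)CC1` is not yet measured in this assay. It differs from compound 3 by hydrogen in place of fluoro on an aromatic carbon. The place description reads the same word for word as for the change from compound 2 to compound 1, so the change is the same one, carried out on the oxan-3-yl core instead of the oxan-4-yl core.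

On that basis the step from compound 3 to compound 4 is expected to be about a 1.5-fold higher number from compound 3 to compound 4 (0.17 log units; within the scatter) in this assay, in line with a 1.5-fold higher number from compound 2 to compound 1 (0.17 log units; within the scatter), with the scatter of the assay allowing a wide band. For compound 4 in this assay the estimate is 4.7 h, expected to fall between 2.5 h and 9 h.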

Compound 4, half-life: 3.1 h
Compound 4: the middle estimate sits 1.5-fold (0.18 log units) above what was measured; the measured number falls inside the stated range.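

In this assay, hydrogen in place of fluoro on an aromatic carbon gives a 1.0-fold lower number from compound 3 to compound 4 (0.01 log units; within the scatter) on the oxan-3-yl core, and this agrees with the same change on the oxan-4-yl core: the same change on two cores in this assay, a 1.5-fold higher number (0.17 log units; within the scatter) from compound 2 to compound 1 and a 1.0-fold lower number (0.01 log units; within the scatter) from compound 3 to compound 4, 1.5-fold (0.18 log units) apart, within the scatter of two such steps. Oxan-3-yl in place of oxan-4-yl on a carbonyl carbon gives a 2.0-fold lower number from compound 1 to compound 4 (0.31 log units; beyond the scatter), the only step among these compounds printed as beyond the scatter, yet it does not separate from the same change made on the fluoro core: the same change on two cores in this assay, a 1.3-fold lower number (0.13 log units; within the scatter) from compound 2 to compound 3 and a 2.0-fold lower number (0.31 log units; beyond the scatter) from compound 1 to compound 4, 1.5-fold (0.18 log units) apart, within the scatter of two such steps. Both changes therefore carry from one core to the other without a gap beyond the scatter, but this does not show that their sizes are the same on both cores, since each comparison rests on a single pair of steps and a small dependence on the core could not be told from the scatter at this size.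

Still open, as far as these compounds go, is whether a chloro or a nitrile on that aromatic carbon, or an amine or a longer chain on the carbonyl carbon in place of the oxanyl group, would behave in the same way. Also open, from the compounds shown here alone, is whether the modest step between the two oxanyl groups would hold at other doses or by other routes.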